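A few compounds are considered here, and "the series" means these few. Any claim that something is new, unique, unknown or untested is made for them only; others in the source may bear on it.

Of the compounds shown here, two have been measured so far in a functional assay on HT-29 cells (Homo sapiens) for inhibition, read by MTT assay, with a stated time of 72 h; a higher number here means a weaker inhibitor, a lower number a stronger inhibitor. Compound 1 `COc1cc2c(Oc3ccc(NC(=O)c4nn(-c5cccc(F)c5)c(=O)cc4C)cc3F)ccnc2cc1OCCCN1CCN(C)CC1` gives 250 nM in this assay, and compound 2 `COc1ccc(-n2nc(C(=O)Nc3ccc(Oc4ccnc5cc(OCCCN6CCCC6)c(OC)cc45)c(F)c3)c(C)cc2=O)cc1` gives 3300 nM. Compound 2 therefore holds the higher of the two numbers, and its gap to compound 1 lies beyond the usual scatter of repeated measurements; since the two differ in more than one place, nothing more than that comparison can be drawn from them.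

Compound 3 `COc1ccc(-n2nc(C(=O)Nc3ccc(Oc4ccnc5cc(OCCCN6CCN(C)CC6)c(OC)cc45)c(F)c3)c(C)cc2=O)cc1` has not yet been measured. It differs from compound 2 in one place: 4-methylpiperazin-1-yl in place of pyrrolidin-1-yl on a saturated chain carbon, three bonds along the chain from an oxygen on an aromatic ring. Compound 1 carries the same 3-(4-methylpiperazin-1-yl)propyl chain as compound 3, but it is not a single-change neighbour of either, so its value cannot be read as the size of this step. The change sits at the far end of a chain, away from the amide part of the molecule. A small step is expected, if any, and leaning towards a lower number, though it may well stay within the scatter. The step from compound 2 to compound 3 in this assay is estimated as a 1.7-fold lower number from compound 2 to compound 3 (0.22 log units; within the scatter). For compound 3, the expected value in this assay is 2000 nM, with a likely range from 600 nM to 6000 nM.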

Compound 3, half-maximal inhibitory concentration: 3520 nM
Estimate against measurement, compound 3: 1.8-fold (0.25 log units) below, and the stated range covers the measured number.
By their numbers in this assay, from the lowest: compound 1; then compounds 2 and 3 (each within the scatter of the next).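

In this assay the step is a 1.1-fold higher number from compound 2 to compound 3 (0.03 log units; within the scatter) and it shows that, with 4-methoxyphenyl on the aromatic nitrogen, this position on the saturated chain carbon takes either pyrrolidin-1-yl or 4-methylpiperazin-1-yl without a difference the assay can resolve. The larger ring, with its second nitrogen, leaves the read-out where it was for this pair. Compound 3 also gives compound 1 its first single-change neighbour, and the step of a 14-fold higher number from compound 1 to compound 3 (1.15 log units; beyond the scatter) comes with 4-methoxyphenyl in place of 3-fluorophenyl on an aromatic nitrogen, so within this pair a large change is tied to that site, while the chain end shows none in the pair where it alone changes.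

The compounds shown leave open whether the chain end would be as undemanding with 3-fluorophenyl on the aromatic nitrogen, and whether a morpholin-4-yl ring, a dimethylamino group or a longer chain would fit the same pattern. They also leave open how other groups on that nitrogen, such as an unsubstituted phenyl or a 4-fluorophenyl, would compare. Nothing available bears on why either step has the size it has.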